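The source may hold more compounds than are shown below. What is called first, only, known or untested is meant among the compounds shown, and "the series" means these compounds.

Going by the values given here, compound 2, with structure `COc1ncnc2c1c(-c1ccsc1)cn2[C@@H]1O[C@H](CO)[C@@H](O)[C@H]1O`, is one of only two compounds here that give a number in a functional assay on CCRF-CEM cells (Homo sapiens), read by MTT assay, with a stated time of 72 h; a higher number here means a weaker inhibitor, a lower number a stronger inhibitor: compound 2 gives 2570 nM. The other number belongs to compound 3, with structure `CN(C)c1ncnc2c1c(-c1ccsc1)cn2[C@@H]1O[C@H](CO)[C@@H](O)[C@H]1O`, which in this assay gives 3480 nM; the step of a 1.4-fold higher number from compound 2 to compound 3 (0.13 log units; within the scatter) is too small to separate the two. Compound 1, with structure `Nc1nc(N)c2c(-c3ccsc3)cn([C@@H]3O[C@H](CO)[C@@H](O)[C@H]3O)c2n1`, gives only a limit of the assay rather than a number, > 20000 nM, so compound 1 shows only that (the limit of > 20000 nM in this assay, at which 1 of the 3 values shown sits).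

Compound 4, with structure `COc1ncnc2c1c(-c1ccoc1)cn2[C@@H]1O[C@H](CO)[C@@H](O)[C@H]1O`, has not been measured in this assay. It differs from compound 2 in one place: furan-3-yl in place of thiophen-3-yl on an aromatic carbon. Among the compounds with values here, no measured step here exchanges the five-membered aromatic ring attached to the core, so none bears directly on this change. Within the data shown here, the only measured step among numbers, from compound 2 to compound 3, altered a different position and stayed within the scatter, which gives no sign that a small change at the edge of this scaffold moves the number far. The step from compound 2 to compound 4 is therefore expected to be modest and uncertain in direction, a 1.4-fold higher number from compound 2 to compound 4 (0.13 log units; within the scatter). In this assay compound 4 is estimated at 3500 nM, with a range from 1500 nM to 9000 nM.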

Compound 4, half-maximal inhibitory concentration: 110 nM
Estimate against measurement, compound 4: 32-fold (1.50 log units) above; the whole stated range lies above it.
By their numbers in this assay, from the lowest: compound 4; then compounds 2 and 3 (each within the scatter of the next). At a limit, above all of these: compound 1.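

Exchanging thiophen-3-yl for furan-3-yl gives a 23-fold lower number from compound 2 to compound 4 (1.37 log units; beyond the scatter) in this assay and shows that the number is highly sensitive to the group at this position, on an aromatic carbon of the five-membered ring with 1 nitrogen. The earlier compounds shown here could not show this, as all of them carry thiophen-3-yl there and differ only elsewhere. The two groups have the same count of heavy atoms, the same ring size, the same counts of donors and acceptors and no net charge, so the large step goes with one ring atom, oxygen in place of sulfur, yet nothing measured here says why that exchange matters so much.

The compounds shown leave open whether furan-3-yl would bring a similar step on the core of compound 3, which carries dimethylamino in place of methoxy, or on the core of compound 1. They also leave open how other groups at this position would compare, such as furan-2-yl, thiophen-2-yl, pyrrole or phenyl.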